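A few compounds are considered here, and "the series" means these few. Any claim that something is new, unique, unknown or untested is made for them only; others in the source may bear on it.

In an assay on CHO-K1 cells for antagonist activity at adenosine receptor A1 (Homo sapiens), read by a beta-galactosidase reporter, with stated times of 15 min and 6 h (a lower number here means a stronger inhibitor, a higher number a weaker inhibitor), compound 2 `Nc1nc(-c2ccc(Cl)o2)nc2sc(CN3CCC(F)CC3)cc12` gives 1080 nM. Compound 2 stands second highest of the three numbers measured: compound 1 `Nc1nc(-c2ccc(Cl)o2)nc2sc(CN3CCCCCC3)cc12` gives 1420 nM, and the step of a 1.3-fold lower number from compound 1 to compound 2 (0.12 log units; within the scatter) is within the scatter, so the two show the same level. Compound 3 `Nc1nc(-c2ccc(Cl)o2)nc2sc(CN3CC=CCC3)cc12` gives 190 nM, and the step of a 5.7-fold lower number from compound 2 to compound 3 (0.75 log units; beyond the scatter) is beyond the scatter, as is a 7.5-fold lower number from compound 1 to compound 3 (0.87 log units; beyond the scatter).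

Compound 4 `N#Cc1ccc(-c2nc(N)c3cc(CN4CCC(F)CC4)sc3n2)cc1` differs from compound 2 in one place: 4-cyanophenyl in place of 5-chlorofuran-2-yl on an aromatic carbon. Within the data shown here, none of the measured steps touches this place; all three vary the ring on the saturated chain carbon, while the aromatic group between the two ring nitrogen atoms is the same chlorofuran in compounds 1, 2 and 3. The measured steps therefore give no direct guide to the size or direction of the change from compound 2 to compound 4, only a sense that single changes in this series can move this assay by a modest amount.

With no anchor for this change, compound 4 is expected to stay near the level of compound 2, with a wide range on either side; the estimated step of a 1.4-fold higher number from compound 2 to compound 4 (0.14 log units; within the scatter) is expected to be small. In this assay compound 4 is estimated at 1500 nM, with a range from 300 nM to 8000 nM.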

Compound 4, inhibition constant: 8430 nM
For compound 4 the middle estimate is 5.6-fold (0.75 log units) below the measured one; the measured number lies above the stated range.
By their numbers in this assay, from the lowest: compound 3; then compounds 2 and 1 (each within the scatter of the next); then compound 4.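

In this assay, 4-cyanophenyl in place of 5-chlorofuran-2-yl on the aromatic carbon between two ring nitrogen atoms gives a 7.8-fold higher number from compound 2 to compound 4 (0.89 log units; beyond the scatter), which shows that this position, the same in compounds 1, 2 and 3, also moves the number. The step is marked modest, as is a 5.7-fold lower number from compound 2 to compound 3 (0.75 log units; beyond the scatter), but it runs towards a weaker inhibitor, whereas that change at the ring on the saturated chain carbon runs towards a stronger one, so both places can shift the number in this small set. Nothing shown here accounts for the step at the aromatic carbon.

From the compounds shown here alone, with only these two groups at this position, it stays open whether the step follows from the six-membered aromatic ring, the nitrile or the absence of chlorine, and groups such as 5-methylfuran-2-yl, unsubstituted phenyl or 4-chlorophenyl would help to separate these. Going by these compounds, it also stays open whether 4-cyanophenyl would give a step of similar size and direction on the ring carried by compound 3.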